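Swapping Methyl for Chloro: From Compound 2 to Compound 4

The source may hold more compounds than are shown below. What is called first, only, known or untested is meant among the compounds shown, and "the series" means these compounds.

Compound 1 `CC1CCN(C2CCN(S(=O)(=O)c3ccc(C(C)(C)C)cc3)CC2)CC1`: in a functional assay on DLD-1 cells (Homo sapiens) for antiproliferative activity, read by CellTiter-Glo, with a stated time of 72 h (on this read-out lower numbers stand for stronger inhibition and higher numbers for weaker inhibition), compound 1 reaches only the assay limit of > 5000 nM, which is a limit rather than a number.
Compound 2 `Cc1ccc(-c2ccccc2S(=O)(=O)N2CCC(N3CCC(C)CC3)CC2)cc1`: compound 2 gives 366 nM.
Compound 3 `CC1CCN(C2CCN(S(=O)(=O)c3ccc(OCc4ccccc4)cc3)CC2)CC1`: compound 3 gives 385 nM.

Compound 2 and compound 3 give values that lie within the usual scatter of each other, so neither can be set apart on these numbers. Among the measured compounds shown here, the one step measured so far, an at least 12-fold lower number from compound 1 to compound 3 (1.11 log units; beyond the scatter), exchanges a tert-butyl for a benzyloxy group and is therefore a different kind of change from the one considered here.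

Compound 4 `CC1CCN(C2CCN(S(=O)(=O)c3ccccc3-c3ccc(Cl)cc3)CC2)CC1` differs from compound 2 as follows: chloro in place of methyl on an aromatic carbon. For the measured compounds named here, no measured step exchanges methyl for chloro, so there is no direct guide. With the group that leaves and the group that enters both of a single heavy atom and neither adding a donor or acceptor, the expected step of a 1.0-fold lower number from compound 2 to compound 4 (0.02 log units; within the scatter) is small, and within scatter of compound 2. Compound 4 is therefore estimated at 350 nM, between 120 nM and 1000 nM.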

Compound 4, half-maximal inhibitory concentration: 202 nM
Compound 4: the middle estimate sits 1.7-fold (0.24 log units) above what was measured, within the range that was stated.
By their numbers in this assay, from the lowest: compounds 4, 2 and 3 (each within the scatter of the next). At a limit, above all of these: compound 1.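

Among the compounds shown here, this is the first change measured at this place, an aromatic carbon para to a large group, and it gives a 1.8-fold lower number from compound 2 to compound 4 (0.26 log units; within the scatter) in this assay. Going from 4-methylphenyl to 4-chlorophenyl therefore keeps the activity, and compound 2 and compound 4 cannot be set apart on these numbers, so chloro can stand here in place of methyl without a loss beyond the scatter. Nothing in the data shown bears on why these two groups read alike.

Whether this place accepts only groups of a single heavy atom stays open, since a methoxy group, a primary amine or a carboxylic acid on this carbon does not appear among the compounds shown. Also open, from the compounds shown here alone, is whether fluoro or bromo would read like chloro in this assay.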